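Bromo in Place of Chloro on the Aryl Ring of Compound 3

A few compounds are considered here, and "the series" means these few. Any claim that something is new, unique, unknown or untested is made for them only; others in the source may bear on it.

Compound 1 `N/N=C1\C(=O)Nc2ccc(S(=O)(=O)N3CCOCC3)cc21` gives 32400 nM in a functional assay on HepG2 cells (Homo sapiens) for cytotoxicity, read by sulforhodamine B assay, with a stated time of 24 h; on this read-out lower numbers stand for stronger inhibition and higher numbers for weaker inhibition.
Compound 2 `O=C1Nc2ccc(S(=O)(=O)N3CCOCC3)cc2/C1=N/NC(=O)c1ccccc1` gives 18100 nM in this assay.
Compound 3 `O=C1Nc2ccc(S(=O)(=O)N3CCOCC3)cc2/C1=N/c1ccc(Cl)cc1` gives 11800 nM in this assay.

Among the three measured compounds, compound 3 has the lowest number. Its nearest neighbour is compound 2, and that step, a 1.5-fold lower number from compound 2 to compound 3 (0.19 log units; within the scatter), stays within the scatter, so the two cannot be ranked. The step of a 2.7-fold lower number from compound 1 to compound 3 (0.44 log units; beyond the scatter) does lie beyond the scatter, though only modestly. The remaining step, a 1.8-fold lower number from compound 1 to compound 2 (0.25 log units; within the scatter), is within the scatter.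

Compound 4 `O=C1Nc2ccc(S(=O)(=O)N3CCOCC3)cc2/C1=N/c1ccc(Br)cc1` differs from compound 3 in one place: bromo in place of chloro on an aromatic carbon. Among the compounds with values here, none of the three measured steps bears directly on this change; all of them alter the group on the nitrogen rather than the substituent on the aromatic ring, and no pair of compounds here differs only in a halogen. Within the data shown here, there is therefore no measured precedent for a shift in either direction, and the step of a 1.1-fold lower number from compound 3 to compound 4 (0.03 log units; within the scatter) is expected to remain within the scatter. On that basis compound 4 is estimated at 11000 nM in this assay, with a range from 5000 nM to 25000 nM.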

Compound 4, half-maximal inhibitory concentration: 11900 nM
For compound 4 the middle estimate is 1.1-fold (0.03 log units) below the measured one; measured number inside the range.
By their numbers in this assay, from the lowest: compounds 3, 4, 2 and 1 (each within the scatter of the next, the first and the last beyond it).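

Within the data shown here, compound 4 gives the first direct reading of a halogen exchange on this aromatic carbon, para to a large group: in this assay, bromo in place of chloro leaves the two compounds indistinguishable (a 1.0-fold higher number from compound 3 to compound 4 (0.00 log units; within the scatter)), whereas the earlier steps altered only the group on the double-bonded nitrogen. The 4-bromophenyl compound also relates to the other two compounds as the 4-chlorophenyl compound does, remaining within the scatter of the benzamido compound (a 1.5-fold lower number from compound 2 to compound 4 (0.18 log units; within the scatter)) and lying modestly beyond the scatter of the amino compound (a 2.7-fold lower number from compound 1 to compound 4 (0.43 log units; beyond the scatter)). No supporting measurement is available to explain why these two halogens give such similar readings.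

With only chloro and bromo shown here, it remains open whether fluoro, methoxy, an amine or a carboxylic acid at the same place would give a number distinguishable from those of compound 3 and compound 4. The same is true of an unsubstituted phenyl group on the double-bonded nitrogen, and these compounds do not show whether the match between the two halogens would hold elsewhere on the aromatic ring.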